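From compound 2 to compound 4: methoxy gives way

The source may report more compounds than this note shows. Statements on the series, on what has been measured and on what is new or still open speak of the compounds shown alone.

compound 1 `Fc1ccc(/C=N/Nc2nc(-c3ccc(C(F)(F)F)cc3)cs2)cc1F`: 79500 nM
compound 2 `COc1ccccc1-c1csc(N/N=C/c2ccc(F)c(F)c2)n1`: > 100000 nM
compound 3 `COc1cc(/C=N/Nc2nc(-c3ccc(F)c(F)c3)cs2)c(Br)c(Br)c1OC`: 54700 nM

These values come from an ADME assay on HUVEC cells (Homo sapiens) for inhibition, read by MTT assay, with a stated time of 48 h; a lower number here means a stronger inhibitor, a higher number a weaker inhibitor. Compound 2 gives > 100000 nM, which is a limit of the assay and not a number. Compound 4 `Fc1ccc(/C=N/Nc2nc(-c3ccccc3)cs2)cc1F`, not yet measured, has hydrogen in place of methoxy on an aromatic carbon, turning 2-methoxyphenyl into phenyl (hydrogen in place of methoxy on an aromatic carbon). Going by the values given here, no two measured compounds differ in one place only, so the size of this change has not been seen directly. Among the compounds with values here, the only numbers to go on are that compound 1 gives 79500 nM and compound 3 gives 54700 nM. The expected step of an at least 1.4-fold lower number from compound 2 to compound 4 (0.16 log units; that floor lies within the scatter) is no larger than the usual scatter. For compound 4 the estimate is 68000 nM, with an expected range of 35000 nM to 120000 nM.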

Compound 4, half-maximal inhibitory concentration: > 100000 nM
Compound 4: a limit, no number; the forecaster's own chance of this, stated with the estimate: 25%; at least 1.4-fold (0.16 log units) between middle value and limit.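

In this assay, compound 4 joins compound 2 at a limit of the assay, not a number: the limit of > 100000 nM in this assay, at which 2 of the 4 values shown sit. The step for hydrogen in place of methoxy cannot be read, but this change does not bring the value down to a readable number. Hydrogen in place of trifluoromethyl gives the one readable step, an at least 1.2-fold higher number from compound 1 to compound 4 (0.09 log units; that floor lies within the scatter), the first direct comparison between two measured compounds here, though it establishes nothing beyond the scatter.

On these data alone, the true size of the methoxy change stays open. So does whether an amine or a carboxylic acid on this ring would give a readable number.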